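Adding a Second Chloro Group: Effect on Cell Growth Inhibition

The source may hold more compounds than are shown below. What is called first, only, known or untested is meant among the compounds shown, and "the series" means these compounds.

Measured compounds:
compound 1, `ClCc1ccccc1Cn1cnc2c(Cl)nc(Cl)nc21`, 1510 nM
compound 2, `ClCc1ccccc1Cn1cnc2c(Cl)ncnc21`, 2040 nM
compound 3, `ClCc1cccc(Cn2cnc3ncnc(Cl)c32)c1`, 1230 nM

All three were tested in a functional assay on NCI-H23 cells (Homo sapiens) for cytotoxicity, read by sulforhodamine B assay, with a stated time of 48 h; a lower number here means a stronger inhibitor of growth, a higher number a weaker inhibitor of growth. Compound 2 and compound 1 share a core and differ in one place: chloro in place of hydrogen on an aromatic carbon. That change gave a 1.4-fold lower number from compound 2 to compound 1 (0.13 log units; within the scatter), so the added chloro group made no difference that can be told apart from repeat-to-repeat variation. Compound 3 has the same atoms as compound 2 joined differently; how the two cores differ is not broken down here. Its value sits close to both others, all within the scatter of one another, so no order among the three can be drawn.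

Compound 4, `ClCc1cccc(Cn2cnc3nc(Cl)nc(Cl)c32)c1`, has not yet been measured. It arises from compound 3 by chloro in place of hydrogen on an aromatic carbon, the same change as from compound 2 to compound 1, at a place described in the same words. Because that earlier step was a 1.4-fold lower number from compound 2 to compound 1 (0.13 log units; within the scatter), a step of similar small size is expected, namely a 1.4-fold lower number from compound 3 to compound 4 (0.14 log units; within the scatter). Compound 4 is therefore estimated at 900 nM in this assay, with a range from 400 nM to 2000 nM. This rests on a single precedent, which is thin ground.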

Compound 4, concentration for 50% growth inhibition: 1540 nM
For compound 4 the middle estimate is 1.7-fold (0.23 log units) below the measured one; the range from low to high includes it.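

In this assay, chloro in place of hydrogen on the second core gave a 1.3-fold higher number from compound 3 to compound 4 (0.10 log units; within the scatter), so this step, like the earlier one, cannot be told apart from repeat-to-repeat variation. Set side by side, the two steps do not differ by more than the assay can resolve: the same change on two cores in this assay, a 1.4-fold lower number (0.13 log units; within the scatter) from compound 2 to compound 1 and a 1.3-fold higher number (0.10 log units; within the scatter) from compound 3 to compound 4, 1.7-fold (0.23 log units) apart, within the scatter of two such steps This shows that the change carried from one core to the other without any step beyond the scatter, but it does not show that the chloro group has no effect at all, and two pairs are too few to predict the step on a further core.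

Still open, as far as these compounds go, is what happens when a group other than chloro stands on this aromatic carbon between two ring nitrogen atoms, for example an amine or a methoxy group. Also open, from the compounds shown here alone, is whether the step remains this small when an amine or a hydroxyl group replaces the chloro group on the side chain.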